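Dropping One Fluorine: From Compound 1 to Compound 3

The compounds below may be only part of what the source reports. "The series", "measured", "known", "first", "only" and "open" are said of these compounds alone.

Measured so far:
compound 1, `Fc1ccc(-c2nnc3sc(/C=C/c4ccco4)nn23)cc1`: 40%
compound 2, `Cc1occc1-c1nnc2sc(CCc3ccccc3)nn12`: 27%

For the measured compounds named here, in an assay for inhibition of histone-lysine N-methyltransferase, H3 lysine-79 specific (Homo sapiens), read by scintillation counting, with stated times of 15 min and 60 min, tested at 100 uM, in the presence of a further agent that is not named here (on this read-out higher numbers stand for a stronger effect at the one concentration tested and lower numbers for a weaker effect), compound 1 gives 40%, the higher of the two numbers measured so far. Compound 2 gives 27%, a gap that lies beyond the usual scatter of this measurement. Going by the values given here, no pair of measured compounds differs in only one place, so no single change has yet been tracked on its own.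

Compound 3, `C(=C/c1nn2c(-c3ccccc3)nnc2s1)\c1ccco1`, has not been measured. It differs from compound 1 in one spot: hydrogen in place of fluoro on an aromatic carbon. The change is small, a hydrogen in place of fluoro on an aromatic carbon, and nothing measured here shows what such a swap does. The step is therefore expected to be small, with no direction that clearly rises above the scatter, perhaps a slight fall. The expected step of a number 6 percentage points lower from compound 1 to compound 3 (within the scatter) is estimated to stay within the scatter. Compound 3 is expected to give about 34%, somewhere between 15% and 55%.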

Compound 3, a percentage reported as inhibition, at one concentration (the size of the read-out at that concentration, not a potency): 81%
Compound 3: middle estimate off by 47 percentage points, on the low side, and the stated range ends below it.
By their numbers in this assay, from the lowest: compound 2; then compound 1; then compound 3.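

In this assay, for the compounds shown here, the swap of 4-fluorophenyl to phenyl brings a number 41 percentage points higher from compound 1 to compound 3 (beyond the scatter), the first single change that can be followed on its own. This place on the six-membered aromatic ring, para to a large group, is therefore far from indifferent: exchanging one fluorine for one hydrogen, with the rest of the molecule unchanged, is enough to move this single-concentration read-out well beyond the scatter, and the unsubstituted phenyl gives the stronger effect. Nothing measured here speaks to the reason for this step.

The compounds shown leave open whether a chlorine, a methyl or an amine at this place would read closer to compound 1 or to compound 3. They also leave open whether the same swap would have a similar effect with the side chain of compound 2.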